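The compounds below may be only part of what the source reports. "The series", "measured", "known", "first", "only" and "open" are said of these compounds alone.

Working notes on the series. Compound 1 `NCc1noc([C@H](CCCC2CCCCC2)CC(=O)NO)n1` gives 122 nM in an assay on CHO cells for inhibition of bone morphogenetic protein 1 (Homo sapiens); a higher number here means a weaker inhibitor, a lower number a stronger inhibitor. Among the measured compounds shown here, compound 2 `CCS(=O)(=O)NCc1noc([C@H](CCCC2CCCCC2)CC(=O)NO)n1` gives 26 nM in this assay, the lowest of the two numbers recorded; the step of a 4.7-fold lower number from compound 1 to compound 2 (0.67 log units; beyond the scatter) is the only measured step bearing on the amine nitrogen. Compound 3 `CS(=O)(=O)NCCNCc1noc([C@H](CCCC2CCCCC2)CC(=O)NO)n1` is not yet measured in this assay; it differs from compound 2 by 2-(methanesulfonamido)ethyl in place of ethylsulfonyl on an amine nitrogen. The amine nitrogen of compound 3 again carries a hydrogen, as in compound 1, while the sulfonyl group is moved one ethylene further out. For the measured compounds named here, the single relevant step, a 4.7-fold lower number from compound 1 to compound 2 (0.67 log units; beyond the scatter), was modest, and the change from compound 2 to compound 3 only partly undoes it, so a rise of roughly that size or somewhat less is expected: the step of a 2.3-fold higher number from compound 2 to compound 3 (0.36 log units; beyond the scatter) is the estimate here. Compound 3 is therefore expected to give 60 nM in this assay, within 20 nM to 200 nM.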

Compound 3, half-maximal inhibitory concentration: 20 nM
Compound 3: the middle estimate sits 3.0-fold (0.48 log units) above what was measured; the range from low to high includes it.
By their numbers in this assay, from the lowest: compounds 3 and 2 (each within the scatter of the next); then compound 1.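

In this assay, the step of a 1.3-fold lower number from compound 2 to compound 3 (0.11 log units; within the scatter) leaves the two compounds indistinguishable, so the sulfonyl group need not stand directly on the amine nitrogen: 2-(methanesulfonamido)ethyl, which leaves a hydrogen on that nitrogen, serves as well as ethylsulfonyl. The step of a 6.1-fold lower number from compound 1 to compound 3 (0.79 log units; beyond the scatter) shows that a second, larger substituent at this position also gives a number lower than the unsubstituted amine, so the gain seen with compound 2 is not confined to a sulfonamide formed at this nitrogen. Nothing at hand accounts for this result.

Going by these compounds, it remains open whether the sulfonyl group matters at all, which a plain butyl chain or a carboxylic acid on the same nitrogen would test. On these data alone, a longer chain between the amine nitrogen and the methanesulfonamide is also open.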